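This account rests on a few compounds, and the source may have more. Where it says the series, first, only, none or still open, it means among the compounds named here.

Three compounds built on one shared core differ only in the aromatic group carried on an aromatic nitrogen. In a functional assay on PANC-1 cells (Homo sapiens) for inhibition, read by MTT assay, with a stated time of 24 h (on this read-out higher numbers stand for weaker inhibition and lower numbers for stronger inhibition), compound 3 `CC1(C)[C@H]2CC[C@]1(C)N(Cc1cn(-c3ccc(O)cc3)nn1)C(=O)C2` gives 100 nM, the lowest of the three numbers. Compound 1 `CC1(C)[C@H]2CC[C@]1(C)N(Cc1cn(-c3ccccc3F)nn1)C(=O)C2` gives 150 nM in this assay, and compound 2 `CC1(C)[C@H]2CC[C@]1(C)N(Cc1cn(-c3cccc(Cl)c3)nn1)C(=O)C2` gives 260 nM. The spread is small: there is a 1.5-fold lower number from compound 1 to compound 3 (0.18 log units; within the scatter), and a 2.6-fold lower number from compound 2 to compound 3 (0.41 log units; beyond the scatter), so compound 3 is separated from compound 2 but not from compound 1.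

Compound 4 `COc1cccc(-n2cc(CN3C(=O)C[C@@H]4CC[C@@]3(C)C4(C)C)nn2)c1` carries the change (3-methoxyphenyl in place of 4-hydroxyphenyl on an aromatic nitrogen). The two steps that bear on it are the aryl swaps that lead to compound 3: a 1.5-fold lower number from compound 1 to compound 3 (0.18 log units; within the scatter) and a 2.6-fold lower number from compound 2 to compound 3 (0.41 log units; beyond the scatter). Both stay small, and the one that went beyond the scatter moved from a 3-chlorophenyl, the group that compound 2 carries. On that basis compound 4 is expected to sit between compound 3 and compound 2, with an expected step of a 1.7-fold higher number from compound 3 to compound 4 (0.23 log units; within the scatter). Compound 4 is therefore estimated at 170 nM in this assay, within a range from 80 nM to 400 nM.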

Compound 4, half-maximal inhibitory concentration: 860 nM
The estimate for compound 4 lay 5.1-fold (0.70 log units) below the measured number; the whole stated range lies below it.
By their numbers in this assay, from the lowest: compounds 3, 1 and 2 (each within the scatter of the next, the first and the last beyond it); then compound 4.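

In this assay the step of an 8.6-fold higher number from compound 3 to compound 4 (0.93 log units; beyond the scatter) is the largest in the series, so the aryl group on this aromatic nitrogen can move the number further than the first three compounds showed. Compound 4 also stands apart from the other aryl groups, with a 5.7-fold higher number from compound 1 to compound 4 (0.76 log units; beyond the scatter) as a second step beyond the scatter, and it has the highest number of the four. Methoxy in place of chloro gives a 3.3-fold higher number from compound 2 to compound 4 (0.52 log units; beyond the scatter) and so shows that the group itself counts, since both compounds carry their group at the 3 position of the phenyl ring.

From the compounds shown here alone, whether the rise follows the methoxy group or its place on the ring stays open, and a 4-methoxyphenyl, 3-hydroxyphenyl or 3-aminophenyl group would help separate the two. Nothing available here accounts for the shift.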